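The source may report more compounds than this note shows. Statements on the series, on what has been measured and on what is new or still open speak of the compounds shown alone.

Compound 1 `Cc1ccc(NC(=O)c2ncn(CC(=O)NCCn3ccc4c(N)ncnc43)n2)cc1C`: 10900 nM
Compound 2 `CC(C)(C)c1ccc(NC(=O)c2ncn(CC(=O)NCc3ccc4[nH]ncc4c3)n2)cc1`: 22400 nM
Compound 3 `CC(C)(C)c1ccc(NC(=O)c2ncn(CC(=O)NCc3ccc4c(N)nccc4c3)n2)cc1`: 19500 nM

These numbers all come from an assay for inhibition of histone-lysine N-methyltransferase, H3 lysine-79 specific (Homo sapiens), read by luminescence, with a stated time of 1 h; a lower number here means a stronger inhibitor, a higher number a weaker inhibitor. Compound 3 stands second highest of the three. Its nearest neighbour is compound 2, and the gap between them, a 1.1-fold lower number from compound 2 to compound 3 (0.06 log units; within the scatter), is within the scatter. Compound 1 lies furthest away, yet the difference between compound 3 and compound 1 is also within the scatter, so the three cannot be put in a reliable order on these numbers.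

Compound 4 `CC(C)(C)c1ccc(NC(=O)c2ncn(CC(=O)NCCn3ccc4c(N)ncnc43)n2)cc1` has not yet been measured. It differs from compound 3 in one place: a group of 11 heavy atoms (7 carbon, 4 nitrogen; one five-membered aromatic ring with 1 hetero atom, one six-membered aromatic ring with 2 hetero atoms) in place of a group of 11 heavy atoms (9 carbon, 2 nitrogen; one six-membered aromatic ring of carbon only, one six-membered aromatic ring with 1 hetero atom), on a saturated chain carbon bound to an amide-type nitrogen. Within the data shown here, the only measured step at that place is the exchange from compound 2 to compound 3, a 1.1-fold lower number from compound 2 to compound 3 (0.06 log units; within the scatter), which did not reach beyond the scatter. The group that enters in compound 4 is the same one carried by compound 1, which gives 10900 nM with a different group on its amide, and that number and the value of compound 3 sit within the scatter of each other. No movement beyond the scatter is therefore expected. Compound 4 is estimated at 13000 nM, with a range from 5000 nM to 32000 nM, which means an expected step of a 1.5-fold lower number from compound 3 to compound 4 (0.18 log units; within the scatter).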

Compound 4, half-maximal inhibitory concentration: 1000 nM
Compound 4: the middle estimate sits 13-fold (1.11 log units) above what was measured; measured number below the stated range.
By their numbers in this assay, from the lowest: compound 4; then compounds 1, 3 and 2 (each within the scatter of the next, the first and the last beyond it).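

Among these compounds, the place on the saturated chain carbon bound to an amide-type nitrogen looked insensitive while the only known exchange there was a 1.1-fold lower number from compound 2 to compound 3 (0.06 log units; within the scatter), but the group in compound 4 now gives a 20-fold lower number from compound 3 to compound 4 (1.29 log units; beyond the scatter) and a 22-fold lower number from compound 2 to compound 4 (1.35 log units; beyond the scatter). That group does not achieve this on its own: compound 1 carries it too, and exchanging 3,4-dimethylphenyl for 4-(tert-butyl)phenyl on the amide-type nitrogen gives an 11-fold lower number from compound 1 to compound 4 (1.04 log units; beyond the scatter), so among these compounds the large gain appears only where both groups stand together, in compound 4. Nothing here explains why this pairing works.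

From the compounds shown here alone, whether the gain needs tert-butyl itself, or would survive with an isopropyl or a cyclohexyl group in its place, stays open. Also open, going by these compounds, is how 3,4-dimethylphenyl would behave with 1-aminoisoquinolin-6-yl, and whether a longer chain would keep the gain.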